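Cutting back the acetyl chain of compound 3

The source may report more compounds than this note shows. Statements on the series, on what has been measured and on what is new or still open speak of the compounds shown alone.

In a functional assay (trachea) with Cavia porcellus as the target (on this read-out lower numbers stand for an effect already at smaller amounts and higher numbers for an effect only at larger amounts of compound), compound 3 (`CCCn1c(=O)n(CCCCC(C)=O)c(=O)c2[nH]cnc21`) stands lowest of the three at 60 nM while compound 1 (`C=CCn1c(=O)c2[nH]cnc2n(CCC)c1=O`) gives 1600 nM and compound 2 (`CCCn1c(=O)n(CCC#N)c(=O)c2[nH]cnc21`) gives 1700 nM with no real gap between them. Compound 4 (`CCCn1c(=O)n(C)c(=O)c2[nH]cnc21`) differs from compound 3 by hydrogen in place of 3-acetylpropyl on a saturated chain carbon bound to an aromatic nitrogen with hydrogen in place of 3-acetylpropyl on a saturated chain carbon bound to an aromatic nitrogen. For the measured compounds named here, two measured steps bear on this: a 27-fold lower number from compound 1 to compound 3 (1.43 log units; beyond the scatter) and a 28-fold lower number from compound 2 to compound 3 (1.45 log units; beyond the scatter) are both large, whereas a 1.1-fold higher number from compound 1 to compound 2 (0.03 log units; within the scatter) stays within the scatter. Compound 4 lacks the acetyl group, so a similarly large step towards a higher number is expected in this assay for it. The estimate amounts to a 50-fold higher number from compound 3 to compound 4 (1.70 log units; beyond the scatter) in all. For compound 4 the estimated value is 3000 nM with a range of 900 nM to 10000 nM expected.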

Compound 4, half-maximal effective concentration: 1600 nM
The estimate for compound 4 lay 1.9-fold (0.27 log units) above the measured number, and the stated range covers the measured number.
By their numbers in this assay, from the lowest: compound 3; then compounds 1, 4 and 2 (each within the scatter of the next).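

In this assay, hydrogen in place of 3-acetylpropyl gives a 27-fold higher number from compound 3 to compound 4 (1.43 log units; beyond the scatter), which ties the low number of compound 3 to that chain and not merely to a group larger than methyl at this place. Neither cyanomethyl nor vinyl separates from hydrogen here: the steps are a 1.1-fold lower number from compound 2 to compound 4 (0.03 log units; within the scatter) and no change at the digits printed from compound 1 to compound 4 (within the scatter). No measurement on hand gives a reason for the large step. As far as these compounds go, whether the carbonyl or the length of the chain carries it stays open: a plain hexyl chain on the same nitrogen would separate the two.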